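The source may report more compounds than this note shows. Statements on the series, on what has been measured and on what is new or still open speak of the compounds shown alone.

Compound 1 `COc1cccc(CN(C)C(=O)c2c[nH]c3cc(-c4cn[nH]c4)ccc23)c1`: 2 nM
Compound 2 `COc1cccc(CN(CCCN(C)C)C(=O)c2cn(C)c3cc(-c4cn[nH]c4)ccc23)c1`: 1 nM
Compound 3 `COc1cccc(CNC(=O)c2cc3ccc(-c4cn[nH]c4)nc3n2CC2CC2)c1`: 150 nM

In an assay on isolated protein for inhibition of Rho-associated protein kinase 2 (Homo sapiens) (a higher number here means a weaker inhibitor, a lower number a stronger inhibitor), compound 2 shows the lowest number of the three, although compound 1 lies within the usual scatter of it, so the two cannot be ranked; compound 3 sits far higher. Compound 4 `COc1cccc(CNC(=O)c2cn(C)c3cc(-c4cn[nH]c4)ccc23)c1` differs from compound 2 in one place: hydrogen in place of 3-(dimethylamino)propyl on an amide-type nitrogen. Within the data shown here, no measured pair shows this change, so its effect is not known from the data. Since compound 1, which also carries a small amide substituent, gives 2 nM, the step is expected to be small, if anything toward a slightly higher number, and may stay within the scatter. Compound 4 is therefore estimated at 3 nM in this assay, with a range of 1 nM to 10 nM, which corresponds to an expected step of a 3.0-fold higher number from compound 2 to compound 4 (0.48 log units; beyond the scatter).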

Compound 4, half-maximal inhibitory concentration: < 1 nM
Compound 4: only a limit was reported; the forecaster's own chance of this, stated with the estimate: 2%; middle value at least 3.0-fold (0.47 log units) away from the limit.
By their numbers in this assay, from the lowest: compounds 2 and 1 (each within the scatter of the next); then compound 3.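

In this assay compound 4 gives a limit rather than a number: the limit of < 1 nM in this assay, at which 1 of the 4 values shown sits. At this amide-type nitrogen, the 3-(dimethylamino)propyl chain is therefore not needed for a low number, as hydrogen in its place gives a number no higher from compound 2 to compound 4 (the limit leaves the size open). The earlier compounds shown here could not show this, as none of them formed a pair differing only at this nitrogen. Going by these compounds, what a carboxylic acid or a simple longer carbon chain without the amine would do at this nitrogen stays open, and so does the true size of this step.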